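Solubility notes: pyridyl-urea series, compound 4

The compounds below may be only part of what the source reports. "The series", "measured", "known", "first", "only" and "open" are said of these compounds alone.

Measured in a physicochemical assay for solubility, in phosphate buffer, at pH 6.5; on this read-out higher numbers stand for higher solubility and lower numbers for lower solubility:
compound 1 `COC(=O)C1(c2ccc(NC(=O)Nc3cccnc3Oc3ccccc3C(C)(C)C)cc2)CC1`: 1 ug/mL
compound 2 `CC(C)(C)c1ccccc1Oc1ncccc1NC(=O)Nc1ccc(C2(CO)CC2)cc1`: 5 ug/mL
compound 3 `CN(C)CC(C)(C)COc1ccc(NC(=O)Nc2cccnc2Oc2ccccc2C(C)(C)C)cc1`: 103 ug/mL

Compound 3 stands highest of the three numbers, with a 21-fold higher number from compound 2 to compound 3 (1.31 log units; beyond the scatter) and a 100-fold higher number from compound 1 to compound 3 (2.01 log units; beyond the scatter); the remaining step, a 5.0-fold higher number from compound 1 to compound 2 (0.70 log units; beyond the scatter), is smaller. Compound 4 `CC(C)CN1CCC(COc2ccc(NC(=O)Nc3cccnc3Oc3ccccc3C(C)(C)C)cc2)CC1` follows, with 1-isobutylpiperidin-4-yl in place of 1-((dimethylamino)methyl)-1-methylethyl on a saturated chain carbon bound to an oxygen on an aromatic ring. For the measured compounds named here, no measured step exchanges one nitrogen-bearing side chain for another; the two large steps into compound 3 only show that both compounds without such a chain sit far lower. The leaving and entering groups each count one hydrogen-bond acceptor and no donor, so only a small drop is expected, a 1.7-fold lower number from compound 3 to compound 4 (0.23 log units; within the scatter), near the scatter. Compound 4 is therefore estimated at 60 ug/mL, range 15 ug/mL to 250 ug/mL.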

Compound 4, solubility: 27 ug/mL
Compound 4: middle estimate off by 2.2-fold (0.35 log units), on the high side; measured number inside the range.
By their numbers in this assay, from the lowest: compound 1; then compound 2; then compound 4; then compound 3.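

In this assay, (1-isobutylpiperidin-4-yl)methoxy in place of 2-((dimethylamino)methyl)-2-methylpropoxy gives a 3.8-fold lower number from compound 3 to compound 4 (0.58 log units; beyond the scatter), so these two nitrogen-bearing side chains are not interchangeable here despite equal donor and acceptor counts. Compound 4 still stands clear of the two compounds without such a chain, with a 5.4-fold higher number from compound 2 to compound 4 (0.73 log units; beyond the scatter) and a 27-fold higher number from compound 1 to compound 4 (1.43 log units; beyond the scatter). No supporting data bear on the origin of the drop.

Open, as far as these compounds go, is whether the piperidine ring or the isobutyl carries the step. A 1-methylpiperidin-4-yl or a morpholine group at this place would help to separate the two.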